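The source may hold more compounds than are shown below. What is called first, only, known or untested is meant among the compounds shown, and "the series" means these compounds.

Measured in a functional assay on HeLa cells (Homo sapiens) for cytotoxicity, read by MTT assay, with a stated time of 24 h; a lower number here means a stronger inhibitor, a higher number a weaker inhibitor:
- compound 1 `CN1C/C(=C\c2ccc(F)cc2)C(=O)/C(=C/c2cccc([N+](=O)[O-])c2)C1`: 6250 nM
- compound 2 `CN1C/C(=C\c2ccc(Cl)cc2)C(=O)/C(=C/c2cccc([N+](=O)[O-])c2)C1`: > 20000 nM, a limit of the assay and not a number
- compound 3 `CN1C/C(=C\c2cccc([N+](=O)[O-])c2)C(=O)/C(=C/c2ccc(Cl)cc2Cl)C1`: 8900 nM
- compound 4 `CN1C/C(=C\c2cccc(Br)c2)C(=O)/C(=C/c2cccc([N+](=O)[O-])c2)C1`: not yet measured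

Compound 3 stands close to compound 1, the gap being a 1.4-fold higher number from compound 1 to compound 3 (0.15 log units; within the scatter). The move to compound 4 is one swap: 3-bromophenyl in place of 2,4-dichlorophenyl on a double-bonded chain carbon bound to a double-bonded ring carbon. The same group has already been altered in the measured compounds. The steps were an at least 3.2-fold higher number from compound 1 to compound 2 (0.50 log units; beyond the scatter) and an at least 2.2-fold lower number from compound 2 to compound 3 (0.35 log units; beyond the scatter), which run in opposite directions, so they set no trend. For the measured compounds named here, no measured compound carries bromine. The expected result is therefore a 1.1-fold lower number from compound 3 to compound 4 (0.05 log units; within the scatter), with no clear direction and no shift beyond the scatter. For compound 4 the estimate is 8000 nM, with an expected range from 2800 nM to 20000 nM.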

Compound 4, half-maximal inhibitory concentration: 11100 nM
Compound 4: the middle estimate sits 1.4-fold (0.14 log units) below what was measured; the range from low to high includes it.
By their numbers in this assay, from the lowest: compounds 1, 3 and 4 (each within the scatter of the next). At a limit, above all of these: compound 2.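

In this assay, 3-bromophenyl on this double-bonded chain carbon gives a 1.2-fold higher number from compound 3 to compound 4 (0.10 log units; within the scatter) and a 1.8-fold higher number from compound 1 to compound 4 (0.25 log units; within the scatter), so a bromine-bearing ring stays level with the fluorine and dichloro rings. Against compound 2, the comparison gives only an at least 1.8-fold lower number from compound 2 to compound 4 (0.25 log units; that floor lies within the scatter). Compound 2 has a limit and not a number, and it alone stands apart from compound 1: the limit of > 20000 nM in this assay, at which 1 of the 4 values shown sits.

Still open, on these data alone, is whether an amine or a carboxylic acid on this aromatic ring, in place of the halogens, would shift the number beyond the scatter. These compounds also do not explain why compound 2 stands apart.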